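From a trifluoromethyl ether to a fluoro ether

A few compounds are considered here, and "the series" means these few. Any claim that something is new, unique, unknown or untested is made for them only; others in the source may bear on it.

Compound 1 `O=C(Nc1cccc(C(F)(F)F)c1)N[C@H]1CC[C@H](Oc2ccc(C(F)(F)F)cc2)CC1` gives 460 nM in a functional assay on CRL2813 cells (Homo sapiens) for cytotoxicity, read by sulforhodamine B assay, with a stated time of 5 days (on this read-out higher numbers stand for weaker inhibition and lower numbers for stronger inhibition), the lowest of the three numbers in hand. Compound 2 `O=C(Nc1cccc(C(F)(F)F)c1)N[C@H]1CC[C@H](Oc2ccc(OC(F)(F)F)cc2)CC1` gives 690 nM, and compound 3 `O=C(Nc1cccc(I)c1)N[C@H]1CC[C@H](Oc2ccc(F)cc2)CC1` gives 5200 nM. Among the measured compounds shown here, the only single-point step, a 1.5-fold higher number from compound 1 to compound 2 (0.18 log units; within the scatter), alters the aryl ether and stays within the scatter. Compound 4 `O=C(Nc1cccc(C(F)(F)F)c1)N[C@H]1CC[C@H](Oc2cccc(F)c2)CC1` differs from compound 1 by 3-fluorophenyl in place of 4-(trifluoromethyl)phenyl on an oxygen on a saturated carbon. For the measured compounds named here, no measured step tests this change directly; compound 3, which carries a fluorophenyl ether together with a different urea aryl group, sits well above compound 1, but two places differ there, so it guides only loosely. An upward step is therefore expected, a 5.4-fold higher number from compound 1 to compound 4 (0.74 log units; beyond the scatter). Compound 4 is estimated at 2500 nM, with a range from 800 nM to 8000 nM.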

Compound 4, half-maximal inhibitory concentration: 2400 nM
The estimate for compound 4 lay 1.0-fold (0.02 log units) above the measured number; the range from low to high includes it.
By their numbers in this assay, from the lowest: compounds 1 and 2 (each within the scatter of the next); then compound 4; then compound 3.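

In this assay, replacing 4-(trifluoromethyl)phenyl with 3-fluorophenyl on the oxygen gives a 5.2-fold higher number from compound 1 to compound 4 (0.72 log units; beyond the scatter) with the rest of the molecule unchanged. Among the compounds shown here, this shows that the aryl group on this ether oxygen can shift the number beyond the scatter, which the only earlier single-place step did not show. Nothing at hand explains the size of this step. The compounds shown leave open whether losing trifluoromethyl or adding fluorine drives the step. They also leave open how an amine or a carboxylic acid on this phenyl ring would read.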